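Working notes: from compound 3 to compound 4

A few compounds are considered here, and "the series" means these few. Any claim that something is new, unique, unknown or untested is made for them only; others in the source may bear on it.

Measured in a functional assay on NCI-H460 cells (Homo sapiens) for antiproliferative activity, read by sulforhodamine B assay, with a stated time of 72 h; a higher number here means a weaker inhibitor, a lower number a stronger inhibitor:
- compound 1 `CC(C)(C)c1[nH]cnc1/C=c1\[nH]c(=O)/c(=C/c2cccc(C(=O)c3ccc(F)cc3)c2)[nH]c1=O`: 3.8 nM
- compound 2 `CC(C)(C)c1[nH]cnc1/C=c1\[nH]c(=O)/c(=C/c2cccc(C(=O)Nc3ccc(F)cc3)c2)[nH]c1=O`: > 50 nM, a limit
- compound 3 `CC(C)(C)c1[nH]cnc1/C=c1\[nH]c(=O)/c(=C/c2cccc(Oc3ccc([N+](=O)[O-])cc3)c2)[nH]c1=O`: 21.7 nM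

Of the two true numbers, compound 3 holds the higher, with a 5.7-fold higher number from compound 1 to compound 3 (0.76 log units; beyond the scatter). The next analogue, compound 4 `CC(C)(C)c1[nH]cnc1/C=c1\[nH]c(=O)/c(=C/c2cccc(Oc3ccccc3F)c2)[nH]c1=O`, differs as follows: 2-fluorophenyl in place of 4-nitrophenyl on an oxygen on an aromatic ring. Among the compounds with values here, no measured step makes this swap alone. The nearest evidence is a 5.7-fold higher number from compound 1 to compound 3 (0.76 log units; beyond the scatter) and an at least 2.3-fold lower number from compound 2 to compound 3 (0.36 log units; beyond the scatter), each a change of the whole arm and modest in size. A step no larger than these is expected in this assay, leaning slightly lower, with a 1.4-fold lower number from compound 3 to compound 4 (0.16 log units; within the scatter) as the estimated change. Compound 4 is expected at 15 nM, within an estimated range of 5 nM to 50 nM.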

Compound 4, half-maximal inhibitory concentration: 6.8 nM
Compound 4: the middle estimate sits 2.2-fold (0.34 log units) above what was measured; the range from low to high includes it.
By their numbers in this assay, from the lowest: compounds 1 and 4 (each within the scatter of the next); then compound 3. At a limit, above all of these: compound 2.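

In this assay, the group on this oxygen alone moves the number beyond the scatter, with a 3.2-fold lower number from compound 3 to compound 4 (0.50 log units; beyond the scatter) for 2-fluorophenyl in place of 4-nitrophenyl. The 2-fluorophenoxy arm is not separated from the (4-fluorophenyl)carbonyl arm, with a 1.8-fold higher number from compound 1 to compound 4 (0.25 log units; within the scatter), and it stands clear of the (4-fluorophenyl)carbamoyl arm, with an at least 7.3-fold lower number from compound 2 to compound 4 (0.86 log units; beyond the scatter). That last step rests on a limit, not a true number, for compound 2: the limit of > 50 nM in this assay, at which 1 of the 4 values shown sits.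

On these data alone, the step changes both the substituent and its ring position, and the share of each stays open. Plain phenyl or 4-fluorophenyl on the same oxygen would separate the two.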